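A few compounds are considered here, and "the series" means these few. Any claim that something is new, unique, unknown or untested is made for them only; others in the source may bear on it.

Measured compounds:
- Compound 1, `O=C(/C=C1\CCc2ccc(F)cc21)N1CCCC1`, in a functional assay on the whole organism with Rattus norvegicus as the target, at a dose of 20 mg/kg by the oral route (on this read-out higher numbers stand for more inhibition at the one dose given (going by the name of the read-out) and lower numbers for less inhibition), gives 18%.
- Compound 2, `CNC(=O)/C=C1\CCc2ccc(F)cc21`, in this assay gives 38%.
- Compound 3, `O=C(/C=C1\CCc2cc(F)c(F)cc21)NC1CC1`, in this assay gives 48%.

Compound 3 has the highest of the three numbers in this assay. Its nearest neighbour is compound 2, a number lower by an amount within the scatter, so the two cannot be ordered; compound 1 lies further off, lower by an amount beyond the scatter.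

For the measured compounds named here, the one step measured so far, a number 20 percentage points higher from compound 1 to compound 2 (beyond the scatter), concerns the amide substituent on the carbonyl carbon. It says nothing about the aromatic substitution that separates compound 3 from the unmeasured compound 4, `O=C(/C=C1\CCc2ccc(F)cc21)NC1CC1`. That change is hydrogen in place of fluoro on an aromatic carbon. Going by the values given here, compound 4 also differs from compound 1 and from compound 2 at the amide, but no single-point step for those pairs has been measured, so nothing can be drawn from them.

Among the compounds with values here, with no measured step bearing on the removal of the fluoro, no change beyond the scatter is expected in this assay; the number for compound 4 is estimated close to that of compound 3, with a wide range to cover the lack of precedent. Compound 4 is expected to give 42%, between 22% and 62%, which means an expected step of a number 6 percentage points lower from compound 3 to compound 4 (within the scatter).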

Compound 4, a percentage reported as inhibition, in the whole organism at one dose (the size of the read-out at that dose, not a potency): 7%
The estimate for compound 4 lay 35 percentage points above the measured number, and the stated range ends above it.
By their numbers in this assay, from the lowest: compound 4; then compound 1; then compounds 2 and 3 (each within the scatter of the next).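

In this assay, for the compounds shown here, the fluoro on the aromatic carbon ortho to a fluoro group, meta to a fused ring and para to a fused ring turns out to matter: hydrogen in its place gives a number 41 percentage points lower from compound 3 to compound 4 (beyond the scatter), a large step at a site of the ring that no earlier pair had tested. The cyclopropyl amide therefore does not carry the read-out by itself, since with the single fluoro it gives a number 31 percentage points lower from compound 2 to compound 4 (beyond the scatter) for cyclopropyl in place of methyl, a large step, and a number 11 percentage points lower from compound 1 to compound 4 (beyond the scatter) for cyclopropylamino in place of pyrrolidin-1-yl, a modest one, leaving compound 4 the lowest of the series in this read-out. Nothing available here explains the size of the fluoro step or the reversal of the amide ranking relative to compound 3.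

Open, from the compounds shown here alone, is whether the same step would appear with the methylamino or pyrrolidin-1-yl amides, so the fluoro and amide effects cannot yet be treated as independent. Also open, going by these compounds, is whether a chloro, methoxy or nitrile group on this aromatic carbon would behave as the fluoro does or as the hydrogen does.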